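The source may hold more compounds than are shown below. What is called first, only, known or untested is meant among the compounds shown, and "the series" means these compounds.

Measured so far in an assay on tissue (HeLa cells) for inhibition of Indoleamine 2,3-dioxygenase 1 (Homo sapiens), read by spectrophotometry; a lower number here means a stronger inhibitor, a higher number a weaker inhibitor:

compound 1 `O/N=C(/Nc1cccc(F)c1)c1ccc2occc2c1`: 20000 nM
compound 2 `CCCCOc1cccc(N/C(=N/O)c2ccc3occc3c2)c1`: > 30000 nM, which is a limit of the assay rather than a number.

Compound 2 therefore stands at the limit of > 30000 nM in this assay, at which 1 of the 2 values shown sits, and its true value is not known beyond that. Among the compounds with values here, the only measured step in the pair, an at least 1.5-fold higher number from compound 1 to compound 2 (0.17 log units; that floor lies within the scatter), went towards a weaker number, though its floor lies inside the scatter, so the size of that move is uncertain.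

Compound 3 `O/N=C(/Nc1cccc(Oc2ccccc2)c1)c1ccc2occc2c1` differs from compound 2 by phenyl in place of butyl on an oxygen on an aromatic ring. Within the data shown here, no measured step covers this change; the one step available runs from fluoro to butoxy and ends at a limit, giving no footing for a gain. The expected step, a step that the limit leaves unreadable from compound 2 to compound 3, is none beyond the scatter, with a fair chance that compound 3 also returns only a limit. Compound 3 is estimated at 40000 nM, within 15000 nM to 120000 nM.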

Compound 3, half-maximal inhibitory concentration: > 30000 nM
Compound 3 gave a limit, no number (the forecaster's own chance of this, stated with the estimate: 60%); the middle value is on the limit's open side.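

In this assay compound 3 also reads > 30000 nM, a limit of the assay and not a number. Phenyl in place of butyl on this oxygen brings no readable value back, so both ethers in the series now end at the same limit: the limit of > 30000 nM in this assay, at which 2 of the 3 values shown sit. Phenoxy in place of fluoro on this aromatic carbon gives an at least 1.5-fold higher number from compound 1 to compound 3 (0.17 log units; that floor lies within the scatter), so this change, like butoxy, has no fixed size, and the step between the two limits cannot be read.

From the compounds shown here alone, how far compound 2 and compound 3 lie past the limit, and whether they differ at all, stays open. Also open, going by these compounds, is whether a smaller group at this place, such as methoxy, hydroxy or an amine, would return a number rather than a limit.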